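The source may hold more compounds than are shown below. What is called first, only, known or untested is meant among the compounds shown, and "the series" means these compounds.

Measured compounds and values:

Compound 1, `Cc1c(OCCCCOCOc2ccc(C(=O)O)cc2)ccc(C(=O)CC2CCCC2)c1O`: 228 nM
Compound 2, `Cc1c(OCCCCOc2ccccc2C(=O)O)ccc(C(=O)CC2CCCC2)c1O`: 335 nM
Compound 3, `CC(=O)c1ccc(OCCCCOc2ccc(C(=O)O)cc2C)c(C)c1O`: 50 nM

All three values come from an assay on HEK293 cells for positive allosteric modulation of metabotropic glutamate receptor 2 (Rattus norvegicus), read by thallium flux, with a stated time of 2.5 min; a lower number here means that less compound is needed, a higher number that more compound is needed for the effect. Compound 3 stands lowest of the three. Its nearest neighbour is compound 1, and that gap lies beyond the scatter; compound 2 lies further off again, also beyond the scatter. Among the compounds with values here, the one step measured, a 1.5-fold higher number from compound 1 to compound 2 (0.17 log units; within the scatter), concerns the carboxy-bearing aryl ether end and falls within the scatter.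

Compound 4, `Cc1cc(C(=O)O)ccc1OCCCCOc1ccc(C(=O)CC2CCCC2)c(O)c1C`, keeps the aryl ether end of compound 3 and changes the ketone side: cyclopentyl in place of hydrogen on a saturated chain carbon bound to a carbonyl carbon. Within the data shown here, no measured step bears directly on this change, since compounds 1 and 2 already carry the cyclopentylmethyl ketone but differ from compound 3 at the other end as well, so their values show only that the combination with those ether groups gives higher numbers than compound 3 does. Without a step for the cyclopentyl alone, the expectation for compound 4 is a number near that of compound 3, drifting upward, and the estimated step of a 1.6-fold higher number from compound 3 to compound 4 (0.20 log units; within the scatter) is taken as modest. The estimate for compound 4 in this assay is 80 nM, with a range from 25 nM to 300 nM.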

Compound 4, half-maximal effective concentration: 608 nM
Estimate against measurement, compound 4: 7.6-fold (0.88 log units) below; measured number outside the range, above it.
By their numbers in this assay, from the lowest: compound 3; then compounds 1, 2 and 4 (each within the scatter of the next, the first and the last beyond it).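

In this assay, within the data shown here, the acetyl to (cyclopentylmethyl)carbonyl change gives the first direct reading at this position: with the 4-carboxy-2-methylphenyl end held fixed, cyclopentyl in place of hydrogen on a saturated chain carbon bound to a carbonyl carbon is a large step, beyond the scatter (a 12-fold higher number from compound 3 to compound 4 (1.08 log units; beyond the scatter)). With the cyclopentylmethyl ketone kept, the ether end counts for much less: 4-carboxy-2-methylphenyl in place of 2-carboxyphenyl stays within the scatter (a 1.8-fold higher number from compound 2 to compound 4 (0.26 log units; within the scatter)), and 4-carboxy-2-methylphenyl in place of (4-carboxyphenoxy)methyl is only a modest step (a 2.7-fold higher number from compound 1 to compound 4 (0.43 log units; beyond the scatter)), so that end alone does not keep the number low once the cyclopentyl is present. Nothing at hand gives a reason for the size of the step at the ketone side.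

Open, from the compounds shown here alone, is how the number runs between hydrogen and cyclopentyl at this place, for instance with a methyl, an isopropyl or a longer straight chain, and whether a ring bearing an amine or an ether oxygen behaves like the cyclopentyl. Also open, going by these compounds, is whether the same change carries a step of this size when the ether end is 2-carboxyphenyl or (4-carboxyphenoxy)methyl.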